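The compounds below may be only part of what the source reports. "The series", "measured", "known", "first", "only" and "open" are said of these compounds alone.

Compound 1 `c1nc2cc3c(cc2[nH]1)C1CNCC3C1` gives 0.15 nM in an assay on HEK293 cells for binding affinity to Neuronal acetylcholine receptor; alpha4/beta2 (Homo sapiens) (a higher number here means a weaker inhibitor, a lower number a stronger inhibitor), the lowest of the three numbers recorded. Compound 3 `CC(=O)Nc1ccc2c(c1)C1CNCC2C1` gives 75 nM in this assay, a gap far beyond the scatter. Compound 2 `c1ccc(-c2cccc3c2C2CNCC3C2)cc1` gives 1600 nM in this assay, further still from compound 1. Compound 4 `Cc1nc2cc3c(cc2[nH]1)C1CNCC3C1` awaits measurement; it differs from compound 1 by methyl in place of hydrogen on an aromatic carbon. Going by the values given here, no measured pair shows what this change does, so the expectation rests on compound 1 alone, whose 0.15 nM leaves room for a small loss. The expected step in this assay is a 3.3-fold higher number from compound 1 to compound 4 (0.52 log units; beyond the scatter), a modest weakening that may not exceed the scatter. Compound 4 is therefore expected to give 0.5 nM in this assay, within 0.1 nM to 3 nM.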

Compound 4, inhibition constant: 0.1 nM
Estimate against measurement, compound 4: 5.0-fold (0.70 log units) above; low and high end bracket the measured number.
By their numbers in this assay, from the lowest: compounds 4 and 1 (each within the scatter of the next); then compound 3; then compound 2.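

In this assay the methyl group on the aromatic carbon between two ring nitrogen atoms gives a 1.5-fold lower number from compound 1 to compound 4 (0.18 log units; within the scatter) and so leaves the number indistinguishable from that of the unsubstituted compound. The earlier compounds shown here offered no step at this position, and this one shows that it accepts a methyl group without a measurable loss. No measurement shown here explains this result. On these data alone, whether an ethyl group, a phenyl ring or an amine would be accepted at the same carbon remains open.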